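The source may report more compounds than this note shows. Statements on the series, on what has been measured and on what is new or still open speak of the compounds shown alone.

Measured in a functional assay on MCF7 cells (Homo sapiens) for cytotoxicity, read by MTT assay, with a stated time of 72 h; a higher number here means a weaker inhibitor, a lower number a stronger inhibitor:
- compound 1 `N[C@H]1CC[C@H](Nc2c(C(=O)NCc3ccc(F)cc3)nc(Br)c3cccnc23)CC1`: 2000 nM
- compound 2 `N[C@H]1CC[C@H](Nc2c(C(=O)NCc3ccc(Cl)cc3Cl)nc(Br)c3cccnc23)CC1`: "not determined" (no result reported)

Compound 2 has no number, so it gives no starting point for the step to the unmeasured compound 3 `N[C@H]1CC[C@H](Nc2c(C(=O)NCc3cccc(C(F)(F)F)c3)nc(Br)c3cccnc23)CC1`. The structural change is 3-(trifluoromethyl)phenyl in place of 2,4-dichlorophenyl on a saturated chain carbon bound to an amide-type nitrogen. Within the data shown here, no step has been measured, so none beyond the scatter is expected in this assay, in either direction. Among the measured compounds shown here, the only anchor is compound 1 at 2000 nM. For compound 3 the expected value is 2000 nM, with an estimated range of 700 nM to 6000 nM.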

Compound 3, half-maximal inhibitory concentration: 15000 nM
For compound 3 the middle estimate is 7.5-fold (0.88 log units) below the measured one, outside the stated range (above it).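

In this assay the aryl group at this position does affect the read-out: 3-(trifluoromethyl)phenyl in place of 4-fluorophenyl on a saturated chain carbon bound to an amide-type nitrogen gives a 7.5-fold higher number from compound 1 to compound 3 (0.88 log units; beyond the scatter) and thus a weaker inhibitor. Compound 2 has no number, so the step from it to compound 3 cannot be read. Nothing at hand bears on the cause of this step.

Still open, as far as these compounds go, is how an unsubstituted phenyl or a pyridine ring in this place would stand against compound 1 and compound 3. The bromine of the shared core also stays unvaried across the compounds shown.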